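Amine variation on the shared core: toward compound 4

The source may report more compounds than this note shows. Statements on the series, on what has been measured and on what is new or still open speak of the compounds shown alone.

Working notes on the series. All three measured compounds keep the same propanamide with a trifluoromethyl-substituted phenyl and the same fused core, and differ only in the amine on the aromatic carbon next to the ring nitrogen. Compound 1 `O=C(CCc1ccc(C(F)(F)F)cc1)Nc1ccc2nc(N3CCC3)ccc2c1` gives 4 nM in an assay on isolated protein for displacement of a labelled ligand from melanin-concentrating hormone receptor 1 (Homo sapiens); a higher number here means a weaker inhibitor, a lower number a stronger inhibitor. Compound 2 `CN(c1ccc2cc(NC(=O)CCc3ccc(C(F)(F)F)cc3)ccc2n1)C1CCCC1` gives 2 nM in this assay, the step being a 2.0-fold lower number from compound 1 to compound 2 (0.30 log units; within the scatter). Compound 3 `CC(C)C(=O)NC1CCN(c2ccc3cc(NC(=O)CCc4ccc(C(F)(F)F)cc4)ccc3n2)C1` gives 1 nM in this assay, the lowest of the three numbers; it is separated from compound 2 by a 2.0-fold lower number from compound 2 to compound 3 (0.30 log units; within the scatter) and from compound 1 by a 4.0-fold lower number from compound 1 to compound 3 (0.60 log units; beyond the scatter), only the latter lying beyond the scatter.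

Compound 4 `O=C(CCc1ccc(C(F)(F)F)cc1)Nc1ccc2nc(N3CCC4(CCNC4)C3)ccc2c1` differs from compound 3 in a group of 9 heavy atoms (7 carbon, 2 nitrogen; 2 five-membered non-aromatic rings with 1 hetero atom each) in place of a group of 11 heavy atoms (8 carbon, 2 nitrogen, 1 oxygen; one five-membered non-aromatic ring with 1 hetero atom), on an aromatic carbon. Among the compounds with values here, the steps that bear on this change are the two at the same place, a 4.0-fold lower number from compound 1 to compound 3 (0.60 log units; beyond the scatter) and a 2.0-fold lower number from compound 2 to compound 3 (0.30 log units; within the scatter), together with a 2.0-fold lower number from compound 1 to compound 2 (0.30 log units; within the scatter) between the two simpler amines. Three rather different amines thus span a narrow band, with the largest step only modest. The change to compound 4 removes the carbonyl-bearing side group of compound 3 while keeping the donor and acceptor count, so for compound 4 a step of a 3.0-fold higher number from compound 3 to compound 4 (0.48 log units; beyond the scatter) is expected, at most modest and toward a somewhat higher number. Compound 4 is accordingly estimated at 3 nM, in a range from 1 nM to 10 nM.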

Compound 4, half-maximal inhibitory concentration: 0.5 nM
Compound 4: the middle estimate sits 6.0-fold (0.78 log units) above what was measured; measured number outside the range, below it.
By their numbers in this assay, from the lowest: compounds 4, 3, 2 and 1 (each within the scatter of the next, the first and the last beyond it).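

In this assay the position accepts a group with two five-membered non-aromatic rings and no oxygen in place of 3-((isopropylcarbonyl)amino)pyrrolidin-1-yl, with a 2.0-fold lower number from compound 3 to compound 4 (0.30 log units; within the scatter), so the carbonyl-bearing side group of compound 3 is not required for a number at this level. Within the data shown here, the new group does stand clear of the two simpler amines, with a 4.0-fold lower number from compound 2 to compound 4 (0.60 log units; beyond the scatter) and an 8.0-fold lower number from compound 1 to compound 4 (0.90 log units; beyond the scatter), the latter being the largest step so far and widening a band that earlier spanned no more than a 4.0-fold lower number from compound 1 to compound 3 (0.60 log units; beyond the scatter). Nothing shown here accounts for these steps.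

Still open, going by these compounds, is whether a methyl or an acetyl group on the second ring nitrogen of compound 4, or a six-membered piperidine ring in place of one of its five-membered rings, would keep the number at this level. Also open, on these data alone, is whether the same order of amines would hold with a chloro or methoxy group in place of the trifluoromethyl on the phenyl of the propanamide.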